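mGlu5 sulfone series: fluorophenyl analogue of compound 3

This account rests on a few compounds, and the source may have more. Where it says the series, first, only, none or still open, it means among the compounds named here.

Measured so far in an assay on isolated protein for displacement of a labelled ligand from metabotropic glutamate receptor 5 (Homo sapiens), with a stated time of 60 min, tested at 1 uM; a higher number here means more inhibition at the concentration tested (going by the name of the read-out), a lower number less inhibition:
compound 1 `COc1ccc(S(=O)(=O)c2cnc3ccc(F)cc3c2N2CCC(C)CC2)cc1` gives 85%
compound 2 `CC1CCN(c2c(S(=O)(=O)c3ccccc3)cnc3ccc(F)cc23)CC1` gives 40%
compound 3 `Cc1cc(C)cc(S(=O)(=O)c2cnc3ccc(F)cc3c2N2CCC(C)CC2)c1` gives 83%

Compound 3 stands second highest of the three in this assay; compound 1 sits within the scatter of it (a number 2 percentage points lower from compound 1 to compound 3 (within the scatter)), while compound 2 is far lower (a number 43 percentage points higher from compound 2 to compound 3 (beyond the scatter)).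

Compound 4 `CC1CCN(c2c(S(=O)(=O)c3ccc(F)cc3)cnc3ccc(F)cc23)CC1` is the next analogue. Change: 4-fluorophenyl in place of 3,5-dimethylphenyl on a sulfonyl sulfur

For the measured compounds named here, two measured steps bear on it. The step of a number 43 percentage points higher from compound 2 to compound 3 (beyond the scatter) shows a much higher number with 3,5-dimethylphenyl on the sulfonyl sulfur than with phenyl; the step of a number 2 percentage points lower from compound 1 to compound 3 (within the scatter) shows that 4-methoxyphenyl and 3,5-dimethylphenyl give numbers level with each other, within the scatter. Whether 4-fluorophenyl gives a number like those of the substituted rings or like that of phenyl is not settled by these data, so a drop is expected for compound 4, of uncertain size, around a number 21 percentage points lower from compound 3 to compound 4 (beyond the scatter) in this assay.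

For compound 4 the estimate in this assay is 62%, with a range from 38% to 86%.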

Compound 4, a percentage reported as inhibition, at one concentration (the size of the read-out at that concentration, not a potency): 87%
Estimate against measurement, compound 4: 25 percentage points below, and the stated range ends below it.
By their numbers in this assay, from the lowest: compound 2; then compounds 3, 1 and 4 (each within the scatter of the next).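

In this assay, 4-fluorophenyl on the sulfonyl sulfur stands level with 3,5-dimethylphenyl (a number 4 percentage points higher from compound 3 to compound 4 (within the scatter)) and with 4-methoxyphenyl (a number 2 percentage points higher from compound 1 to compound 4 (within the scatter)), while fluoro in place of hydrogen on the aromatic carbon gives a large gain over phenyl (a number 47 percentage points higher from compound 2 to compound 4 (beyond the scatter)). A single fluoro on this ring is therefore enough to reach the level of the other substituted rings, and among these four compounds only unsubstituted phenyl gives a low number. Nothing available explains this.

Open, going by these compounds, is whether a ring carrying an amine or a carboxylic acid, or a saturated cyclohexyl group on the sulfonyl sulfur, would hold this level.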